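Paw edema series: pyrrole in place of furan

This account rests on a few compounds, and the source may have more. Where it says the series, first, only, none or still open, it means among the compounds named here.

Measured so far:
compound 1 `COc1ccc(Cl)c(-c2nnc3sc(Cc4c(C)[nH]c5ccc(OC)cc45)nn23)c1`, 11.3%
compound 2 `COc1ccc(Cc2nnc3n2NC(c2ccco2)S3)cc1OC`, 12%

In a functional assay on the whole organism (strain Wistar Albino) for inhibition, with Rattus norvegicus as the target, read by paw edema, with a stated time of 1 h, at a dose of 20 mg/kg (on this read-out higher numbers stand for more inhibition at the one dose given (going by the name of the read-out) and lower numbers for less inhibition), compound 2 gives 12%, the top of the two numbers in hand, yet compound 1 with 11.3% lies within the scatter of it, so the two cannot be told apart. Compound 3 `COc1ccc(Cc2nnc3n2NC(c2ccc[nH]2)S3)cc1OC` differs from compound 2 by 1H-pyrrol-2-yl in place of furan-2-yl on a saturated ring carbon. Among the compounds with values here, no pair of measured compounds shows what such a change does on this read-out. The change is expected to move the read-out by no change at the digits printed from compound 2 to compound 3 (within the scatter), nothing beyond the scatter. Compound 3 is therefore estimated at 12%, from 3% to 22%.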

Compound 3, a percentage reported as inhibition, in the whole organism at one dose (the size of the read-out at that dose, not a potency): 13.2%
Compound 3: the middle estimate sits 1.2 percentage points below what was measured; low and high end bracket the measured number.
By their numbers in this assay, from the lowest: compounds 1, 2 and 3 (each within the scatter of the next).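

In this assay, within the data shown here, 1H-pyrrol-2-yl in place of furan-2-yl on a saturated ring carbon gives a number 1.2 percentage points higher from compound 2 to compound 3 (within the scatter), the first reading of this change at this position. Exchanging a hydrogen-bond acceptor for a hydrogen-bond donor in this five-membered aromatic ring therefore does not separate the two compounds on this read-out. Nothing at hand bears on the reason for this result.

Going by these compounds, whether any group at this carbon moves the read-out beyond the scatter stays open. A carboxylic acid, an aminomethyl group or a longer alkyl chain there would test this.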